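Replacing 3-chlorophenyl with 4-hydroxyphenyl in compound 2

The source may report more compounds than this note shows. Statements on the series, on what has been measured and on what is new or still open speak of the compounds shown alone.

Values in a functional assay on OVCAR-3 cells (Homo sapiens) for inhibition, read by MTT assay, with a stated time of 24 h; on this read-out higher numbers stand for weaker inhibition and lower numbers for stronger inhibition:
- compound 1 `CC1(C)[C@H]2CC[C@]1(C)N(Cc1cn(-c3ccccc3C#N)nn1)C(=O)C2`: 110 nM
- compound 2 `CC1(C)[C@H]2CC[C@]1(C)N(Cc1cn(-c3cccc(Cl)c3)nn1)C(=O)C2`: 50 nM

Of the two compounds measured in this assay, compound 2 has the lower number, at 50 nM. Compound 3 `CC1(C)[C@H]2CC[C@]1(C)N(Cc1cn(-c3ccc(O)cc3)nn1)C(=O)C2` keeps the shared core and changes the group on the aromatic nitrogen: 4-hydroxyphenyl in place of 3-chlorophenyl on an aromatic nitrogen. For the measured compounds named here, one measured step bears on this, as it changes a group at the same place: a 2.2-fold lower number from compound 1 to compound 2 (0.34 log units; beyond the scatter). That step is modest but beyond the scatter. Going by the values given here, it shows that this position can shift the number, but no measured compound carries 4-hydroxyphenyl, so the direction remains uncertain. A modest move to a higher number, similar in size to that step, is the working expectation. The estimated change is a 2.0-fold higher number from compound 2 to compound 3 (0.30 log units; within the scatter). For compound 3 the expected value is 100 nM, with an estimated range of 30 nM to 320 nM.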

Compound 3, half-maximal inhibitory concentration: 410 nM
The estimate for compound 3 lay 4.1-fold (0.61 log units) below the measured number; the whole stated range lies below it.
By their numbers in this assay, from the lowest: compound 2; then compound 1; then compound 3.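

In this assay, the group on the aromatic nitrogen can move the number further than the earlier pair showed: compare (an 8.2-fold higher number from compound 2 to compound 3 (0.91 log units; beyond the scatter)) with (a 2.2-fold lower number from compound 1 to compound 2 (0.34 log units; beyond the scatter)). Compound 3 also stands above the 2-cyanophenyl compound (a 3.7-fold higher number from compound 1 to compound 3 (0.57 log units; beyond the scatter)), so among these three compounds, 4-hydroxyphenyl gives the highest number. The change from 3-chlorophenyl keeps the printed heavy-atom count and adds a hydrogen-bond donor and acceptor, but no measurement here bears on why the number rose.

Still open, on these data alone, is whether the higher number follows the hydroxy group itself or the different substitution pattern on the phenyl ring. Also open, as far as these compounds go, is whether a methoxy group or an amine on that phenyl ring would give a similar number.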